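Removing the linking nitrogen from compound 1

The source may hold more compounds than are shown below. What is called first, only, known or untested is meant among the compounds shown, and "the series" means these compounds.

Going by the values given here, compound 1 `C[C@H](Nc1cc(=O)oc2cc(OCc3ccccc3)ccc12)C(N)=O` is one of two compounds measured in an assay for inhibition of Amine oxidase [flavin-containing] B (Rattus norvegicus); a higher number here means a weaker inhibitor, a lower number a stronger inhibitor. In this assay compound 1 gives 680 nM, the highest of the two numbers. Compound 2 `NC(=O)Cc1cc(=O)oc2cc(OCc3cccc(Cl)c3)ccc12`, whose amide chain sits directly on the shared core and whose benzyl group carries a chlorine, gives in this assay 30 nM, a lower number that lies beyond the scatter of repeated measurements. Compound 3 `CC(C(N)=O)c1cc(=O)oc2cc(OCc3ccccc3)ccc12` is compound 1 with a single change: 1-carbamoylethyl in place of (1-carbamoylethyl)amino on an aromatic carbon. The chain is thus attached through carbon, as it is in compound 2. Among the compounds with values here, no measured pair isolates this change. The expected step from compound 1 to compound 3 is a modest move toward stronger inhibition, a 2.7-fold lower number from compound 1 to compound 3 (0.43 log units; beyond the scatter), because compound 2 with its carbon-linked chain gives 30 nM. Compound 3 is therefore estimated at 250 nM, within a range of 60 nM to 1000 nM.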

Compound 3, half-maximal inhibitory concentration: 100 nM
For compound 3 the middle estimate is 2.5-fold (0.40 log units) above the measured one; the range from low to high includes it.
By their numbers in this assay, from the lowest: compound 2; then compound 3; then compound 1.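

Going by these compounds alone, compound 1 and compound 3 differ in one place only, so this pair gives the first direct reading of the link between the chain and the shared core: in this assay, putting 1-carbamoylethyl in place of (1-carbamoylethyl)amino gives a 6.8-fold lower number from compound 1 to compound 3 (0.83 log units; beyond the scatter). Compound 2 could not show this, as it also differs from compound 1 in its chlorine-bearing benzyl group and its chain. At this aromatic carbon, opposite the ring oxygen, the linking nitrogen is therefore not required for inhibition, and no measurement here explains the gain.

From the compounds shown here alone, it remains open whether a carboxylic acid in place of the amide, or a longer chain, would be tolerated on this carbon link. Compound 1 has a defined stereocentre and compound 3 does not, so the contribution of that difference to the step also remains unresolved.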